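Adding a side chain to compound 2: expected clearance

The source may report more compounds than this note shows. Statements on the series, on what has been measured and on what is new or still open speak of the compounds shown alone.

In an ADME assay (liver) for metabolic stability, with Liver microsome (Rattus norvegicus) as the target, using microsomes and NADPH, with a stated time of 30 min (on this read-out higher numbers stand for fast clearance and lower numbers for slow clearance), compound 2 `CC#C[C@H]1CN(S(=O)(=O)c2ccc(N)nc2)CCN1c1ccccc1` gives > 399 mL.min-1.g-1, which is a limit of the assay and not a number. Two further members of the series have numerical readings. Compound 1 `CC#C[C@H]1CN(S(=O)(=O)c2ccc(N)nc2)CCN1c1ccc(S(=O)(=O)NC)cn1` gives 42 mL.min-1.g-1 in this assay. Compound 3 `CC#C[C@H]1CN(S(=O)(=O)c2ccc(N)nc2)CCN1c1ncc(C(C)(O)C(F)(F)F)s1` gives 87 mL.min-1.g-1 in the same test.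

Going by the values given here, no two measured compounds differ in one place only, so the effect of a single change cannot be read directly from the series. Compound 4 `C#CCC(O)(c1ccc(N2CCN(S(=O)(=O)c3ccc(N)nc3)C[C@@H]2C#CC)cc1)C(F)(F)F` departs from compound 2 by one change: a group of 9 heavy atoms (5 carbon, 1 oxygen, 3 fluorine; no ring) in place of a hydrogen atom, on an aromatic carbon. The new group stands para to a large group.

A fall in this assay is expected, but its size is poorly defined. This expectation rests on compound 1 at 42 mL.min-1.g-1 and compound 3 at 87 mL.min-1.g-1, each of which carries a substituent on the ring that is unsubstituted in compound 2. Both also differ from compound 2 in the ring itself, so they offer only a loose guide, and a reading at the limit remains possible. The expected change is an at least 2.4-fold lower number from compound 2 to compound 4 (0.39 log units; beyond the scatter). For compound 4 the estimate is 160 mL.min-1.g-1, with an expected range of 70 mL.min-1.g-1 to 400 mL.min-1.g-1.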

Compound 4, intrinsic clearance in microsomes: 59 mL.min-1.g-1
Compound 4: middle estimate off by 2.7-fold (0.43 log units), on the high side; the measured number lies below the stated range.
By their numbers in this assay, from the lowest: compounds 1, 4 and 3 (each within the scatter of the next, the first and the last beyond it). At a limit, above all of these: compound 2.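

In this assay the new group, on an aromatic carbon para to a large group, brings an at least 6.7-fold lower number from compound 2 to compound 4 (0.83 log units; beyond the scatter) and gives the series its first step in one place. Compounds 1 and 3 each differ from compound 2 in the ring as well as in the substituent, whereas here the six-membered aromatic ring of carbon only stays, so the fall is tied to the new group alone. The size of this step is only a bound because compound 2 stands at a limit of the assay and not at a number: (the limit of > 399 mL.min-1.g-1 in this assay, at which 1 of the 4 values shown sits).

The compounds shown leave open which part of the new group goes with the fall, whether the hydroxyl, the trifluoromethyl or the chain with its triple bond. They also leave open whether a simpler group at the same place, such as an amine, a carboxylic acid or a plain alkyl chain, would bring a fall of similar size.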